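A Fluoro Step Repeated on a Different Ring

The source may hold more compounds than are shown below. What is called first, only, known or untested is meant among the compounds shown, and "the series" means these compounds.

The measured compounds and their values:
- compound 1, `O=C(Nc1ccc(-c2cscn2)cc1)C1CCCN(Cc2ccc(F)c(F)c2)C1`: 880 nM
- compound 2, `O=C(Nc1ccc(-c2cscn2)cc1)C1CCCN(Cc2cc(F)c(F)c(F)c2)C1`: 400 nM
- compound 3, `O=C(Nc1ccc(-c2ccc[nH]2)cc1)[C@H]1CCCN(Cc2ccc(F)c(F)c2)C1`: 190 nM

These numbers come from a functional assay on A-375 cells (Homo sapiens) for antiproliferative activity (a higher number here means a weaker inhibitor, a lower number a stronger inhibitor), so compound 3 stands best of the three, and its steps to compound 2 and compound 1 both lie beyond the scatter. Compound 4 is `O=C(Nc1ccc(-c2ccc[nH]2)cc1F)[C@H]1CCCN(Cc2ccc(F)c(F)c2)C1` and has not yet been measured.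

Between compound 1 and compound 2 the change is fluoro in place of hydrogen on an aromatic carbon and it gave a 2.2-fold lower number from compound 1 to compound 2 (0.34 log units; beyond the scatter). Between compound 3 and compound 4 the change is fluoro in place of hydrogen on an aromatic carbon. Both changes put a fluoro in place of a hydrogen on an aromatic carbon, yet the surroundings differ: in compound 2 the new fluoro sits ortho to a fluoro group and meta to a fluoro group and to a large group, whereas in compound 4 it sits ortho to a large group and meta to a 1H-pyrrol-2-yl group. So this is the same kind of change, not the same change. How the core of compound 1 differs from the core of compound 3 is not broken down here.

Within the data shown here, only one earlier step of this kind exists, and it sits in different surroundings, so the expected step for compound 4 is held close to no change, a 1.3-fold lower number from compound 3 to compound 4 (0.10 log units; within the scatter), leaning slightly toward the gain seen from compound 1 to compound 2 because of a 2.2-fold lower number from compound 1 to compound 2 (0.34 log units; beyond the scatter). On this basis compound 4 is estimated at 150 nM, with a likely range from 50 nM to 450 nM.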

Compound 4, half-maximal inhibitory concentration: 130 nM
Compound 4: middle estimate off by 1.2-fold (0.06 log units), on the high side; the range from low to high includes it.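

In this assay, placing a fluoro on an aromatic carbon, ortho to a large group and meta to a 1H-pyrrol-2-yl group, gave a 1.5-fold lower number from compound 3 to compound 4 (0.16 log units; within the scatter), so this step on its own cannot be told apart from the ordinary variation between repeated measurements. Set beside the earlier fluoro step, it gives no sign that the two cores respond differently: the same change on two cores in this assay, a 2.2-fold lower number (0.34 log units; beyond the scatter) from compound 1 to compound 2 and a 1.5-fold lower number (0.16 log units; within the scatter) from compound 3 to compound 4, 1.5-fold (0.18 log units) apart, within the scatter of two such steps. This agreement means that the same kind of change has shown no measurable dependence on the core in these two pairs, but it does not establish that a real gain carries over, as the second step is not separable from the scatter, the two fluoro groups stand on different rings in different surroundings, and two pairs are too few to support a general rule.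

The compounds shown leave open how a chloro, a methyl or a methoxy group on the same aromatic carbon as the new fluoro of compound 4 would read in this assay. They also leave open whether adding the extra fluoro that separates compound 2 from compound 1 to compound 4 would produce a step beyond the scatter.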